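Amide substituent variation toward compound 4

This account rests on a few compounds, and the source may have more. Where it says the series, first, only, none or still open, it means among the compounds named here.

Compound 2 `CNC(=O)/C=C/c1ccncc1-c1ccc2ccccc2c1` is measured in an assay on a protein complex for inhibition of CDK8/Cyclin C (Homo sapiens), with a stated time of 1 h, tested at 10 uM (on this read-out lower numbers stand for less inhibition and higher numbers for more inhibition at the one concentration tested (going by the name of the read-out)), where compound 2 gives 101%. Compound 1 `CN1CCN(C(=O)/C=C/c2ccncc2-c2ccc3ccccc3c2)CC1` gives 101% in this assay, and compound 3 `CCOC(=O)/C=C/c1ccncc1-c1ccc2c(cnn2C)c1` gives 100% in this assay. Compound 2 stands level with compound 1 at the digits shown, the two together the highest of the three numbers, and its gap to compound 3 lies within the scatter.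

The change from compound 2 to compound 4 `O=C(O)[C@@H]1CCCN1C(=O)/C=C/c1ccncc1-c1ccc2ccccc2c1` is 2-carboxypyrrolidin-1-yl in place of methylamino on a carbonyl carbon. Among the compounds with values here, one measured step bears on it, since it also exchanged the group on the carbonyl carbon: no change at the digits printed from compound 1 to compound 2 (within the scatter). Within the measured compounds, then, exchanging the group on the carbonyl carbon left the read-out unchanged, with every compound level in this assay. Within the data shown here, no measured compound carries a carboxylic acid, so that part of the entering group is untested here.

The expected step in this assay is therefore none beyond the scatter, a number 4 percentage points lower from compound 2 to compound 4 (within the scatter), with the range widened downward to allow for the untested acid. Compound 4 is estimated at 97% in this assay, between 80% and 102%.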

Compound 4, a percentage reported as inhibition, at one concentration (the size of the read-out at that concentration, not a potency): 67%
The estimate for compound 4 lay 30 percentage points above the measured number; measured number below the stated range.
By their numbers in this assay, from the lowest: compound 4; then compounds 3, 1 and 2 (each within the scatter of the next).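

In this assay, replacing methylamino on the carbonyl carbon with 2-carboxypyrrolidin-1-yl gives a number 34 percentage points lower from compound 2 to compound 4 (beyond the scatter) and replacing 4-methylpiperazin-1-yl with the same group gives a number 34 percentage points lower from compound 1 to compound 4 (beyond the scatter) as the second step into this group. Within the data shown here, the position therefore does respond to the group it carries, a response that the earlier exchange, no change at the digits printed from compound 1 to compound 2 (within the scatter) as its only step, gave no sign of, and the two amides methylamino and 4-methylpiperazin-1-yl do not speak for every group at this place. No measurement bearing on the origin of this drop is available.

The entering group brings a five-membered ring, a carboxylic acid and a defined stereocentre together, and the compounds shown do not separate their contributions to the step. Plain pyrrolidin-1-yl on the carbonyl carbon, the methyl ester of the acid, or the other stereoisomer of the 2-carboxypyrrolidin-1-yl group would divide the step among these parts, while a read-out at one concentration leaves the size of the potency difference open.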